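Halogen swap on the pendant aryl of the shared core

This account rests on a few compounds, and the source may have more. Where it says the series, first, only, none or still open, it means among the compounds named here.

Compound 1 `Fc1ccc(-c2nc3sc(Cc4ccc(Cl)cc4)nn3c2Br)cc1` and compound 2 `Clc1ccc(Cc2nn3c(Br)c(-c4ccc(Cl)cc4)nc3s2)cc1` share one core and differ only by chloro in place of fluoro on an aromatic carbon. In a functional assay on HeLa cells (Homo sapiens) for cytotoxicity, with a stated time of 72 h (on this read-out higher numbers stand for weaker inhibition and lower numbers for stronger inhibition), compound 1 gives > 250000 nM, a limit of the assay rather than a number. In this assay compound 2 gives > 250000 nM, likewise only a limit. The step that the two limits leave unreadable from compound 1 to compound 2 is therefore not readable in size or direction because of the limit of > 250000 nM in this assay, at which 2 of the 2 values shown sit. Compound 3 `Clc1ccc(Cc2nn3c(Br)c(-c4ccc(Br)cc4)nc3s2)cc1` carries bromo in place of chloro on an aromatic carbon. Within the data shown here, the one measured step that bears on this change, from compound 1 to compound 2, gives no readable size, so it supplies neither a direction nor a magnitude for the new step. With compound 2 standing at the limit of this assay, compound 3 is expected to remain at that limit as well, the step that the limit leaves unreadable from compound 2 to compound 3 being expected to stay within the scatter. For compound 3 the estimate in this assay is 300000 nM, within a range of 60000 nM to 1500000 nM.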

Compound 3, half-maximal inhibitory concentration: 188000 nM
Compound 3: the middle estimate sits 1.6-fold (0.20 log units) above what was measured; low and high end bracket the measured number.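

In this assay, among these compounds, compound 3 gives 188000 nM as the first value that is a number and not a limit, so this position can yield a readable result. The change from 4-chlorophenyl to 4-bromophenyl gives an at least 1.3-fold lower number from compound 2 to compound 3 (0.12 log units; that floor lies within the scatter) and bromo in place of fluoro on the same aromatic carbon gives an at least 1.3-fold lower number from compound 1 to compound 3 (0.12 log units; that floor lies within the scatter) and neither floor shows a change beyond the scatter. Both steps remain floors without an upper size because one compound in each pair sits at a limit: the limit of > 250000 nM in this assay, at which 2 of the 3 values shown sit.

The step from fluoro to chloro cannot be read, so these two halogens remain unordered at this position. Also open, as far as these compounds go, is what an amine, a carboxylic acid or a longer chain such as butyl would give on this aromatic carbon in place of a halogen.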